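The source may report more compounds than this note shows. Statements on the series, on what has been measured and on what is new or still open speak of the compounds shown alone.

Working notes on the series. Compound 1 `Cn1c(=O)[nH]c2c(cnn2-c2ccc(Br)cc2)c1=N` gives 34% in an assay on membranes from brain for binding affinity to adenosine receptor A1 (Rattus norvegicus), read by radioligand binding, tested at 20 uM (a higher number here means more inhibition at the concentration tested (going by the name of the read-out), a lower number less inhibition), and compound 3 `CCCCn1c(=O)[nH]c2c(cnn2-c2cccc(Cl)c2)c1=N` gives 58% in this assay. Compound 2 `Cn1c(=O)[nH]c2c(cnn2-c2ccccc2F)c1=N` gives 8% in this assay, the lowest of the three numbers: compound 1 stands higher by a gap beyond the scatter, compound 3 higher still. Compound 4 `Cn1c(=O)[nH]c2c(cnn2-c2ccccc2Cl)c1=N` differs from compound 2 in one place: chloro in place of fluoro on an aromatic carbon. Among the measured compounds shown here, no pair of measured compounds isolates this change, so its size is untested here. Compound 3 also carries a chloro, but it differs from compound 2 in several places. In this assay compound 3 gives 58%. A small upward step is expected, barely beyond the scatter. For compound 4 an estimated 20% is expected, in the range 5% to 40%. The estimated step of a number 12 percentage points higher from compound 2 to compound 4 (beyond the scatter) is expected to be modest.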

Compound 4, a percentage reported as inhibition, at one concentration (the size of the read-out at that concentration, not a potency): 7%
Beside the measured number, compound 4's estimate is 13 percentage points above it; the measured number falls inside the stated range.
By their numbers in this assay, from the lowest: compounds 4 and 2 (each within the scatter of the next); then compound 1; then compound 3.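

In this assay, chloro in place of fluoro on an aromatic carbon, ortho to a large group, gives a number 1 percentage points lower from compound 2 to compound 4 (within the scatter). Among the compounds shown here, this is the first pair that isolates the change, and at this position the two halogens cannot be told apart by this read-out. No measured evidence bears on this result. As far as these compounds go, whether an amine or a methoxy group on the same carbon would shift the number remains open. So does whether the chloro and fluoro pair would read alike on the core carrying a longer chain.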